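Chloro-purine benzyl chlorides: amino substitution on the six-membered ring

This account rests on a few compounds, and the source may have more. Where it says the series, first, only, none or still open, it means among the compounds named here.

Measured so far:
compound 1, `ClCc1ccc(Cn2cnc3c(Cl)ncnc32)cc1`, 95500 nM
compound 2, `Nc1nc(Cl)c2ncn(Cc3ccc(CCl)cc3)c2n1`, 57500 nM
compound 3, `ClCc1ccccc1Cn1cnc2c(Cl)ncnc21`, 66100 nM

All three were run in a functional assay on KM12 cells (Homo sapiens) for cytotoxicity, read by sulforhodamine B assay, with a stated time of 48 h; on this read-out higher numbers stand for lower toxicity in this test and lower numbers for higher toxicity in this test. Compound 1 and compound 3 have the same atoms joined differently; the difference between the two cores is not broken down here. Compound 2 differs from compound 1 by amino in place of hydrogen on an aromatic carbon, and the resulting step was a 1.7-fold lower number from compound 1 to compound 2 (0.22 log units; within the scatter).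

Compound 4, `Nc1nc(Cl)c2ncn(Cc3ccccc3CCl)c2n1`, is not yet measured. It differs from compound 3 by amino in place of hydrogen on an aromatic carbon, the same change as that from compound 1 to compound 2. The expected step for compound 4 is a 1.5-fold lower number from compound 3 to compound 4 (0.17 log units; within the scatter), resting on compound 1 and compound 2 having shown a 1.7-fold lower number from compound 1 to compound 2 (0.22 log units; within the scatter). Compound 4 is therefore estimated at 45000 nM, with a likely range from 20000 nM to 100000 nM.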

Compound 4, concentration lethal to 50% of the cells: 97200 nM
Compound 4: middle estimate off by 2.2-fold (0.33 log units), on the low side, and the stated range covers the measured number.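

In this assay, amino in place of hydrogen on an aromatic carbon gives a 1.5-fold higher number from compound 3 to compound 4 (0.17 log units; within the scatter). Set beside the earlier step, the result does not separate the two cores: the same change on two cores in this assay, a 1.7-fold lower number (0.22 log units; within the scatter) from compound 1 to compound 2 and a 1.5-fold higher number (0.17 log units; within the scatter) from compound 3 to compound 4, 2.4-fold (0.39 log units) apart, within the scatter of two such steps The change therefore shows no detectable dependence on the core across these two pairs, but with both steps within the scatter, this does not show that amino shifts the number on either core or that it acts identically on both.

The compounds shown leave open whether a different group in the same place, such as a methylamino or methoxy group, would give a step beyond the scatter. On these data alone, replacing the chloro group with a thiol or a morpholine also remains open.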